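Swapping Methyl for Fluoro on Compound 1

The compounds below may be only part of what the source reports. "The series", "measured", "known", "first", "only" and "open" are said of these compounds alone.

Compound 1 `Cc1cccc(NC(=S)N/N=C/c2ccc3ccccc3n2)c1` was tested in a functional assay on HT-29 cells (Homo sapiens) for antiproliferative activity, read by sulforhodamine B assay, with a stated time of 72 h; a higher number here means a weaker inhibitor, a lower number a stronger inhibitor. In this assay compound 1 gives only a limit, > 100000 nM, so no number is known for it. Compound 1 stands at the limit of > 100000 nM in this assay, at which 1 of the 3 values shown sits. Two other compounds were also measured: compound 2 `NC(=S)N/N=C/c1cc2ccccc2s1` gives 99200 nM, and compound 3 `CN(C)C(=S)N/N=C/c1cnc2ccccc2n1` gives 450 nM. Compound 4 `Fc1cccc(NC(=S)N/N=C/c2ccc3ccccc3n2)c1` has not yet been measured. It differs from compound 1 by fluoro in place of methyl on an aromatic carbon. Within the data shown here, no measured pair of compounds shows this change, so its effect is unknown. The expected step of a number no higher from compound 1 to compound 4 (the limit leaves the size open) is no larger than the usual scatter. Compound 4 is therefore estimated at 100000 nM, between 30000 nM and 300000 nM, and most likely reported again only as a limit.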

Compound 4, half-maximal inhibitory concentration: 74700 nM
Beside the measured number, compound 4's estimate is 1.3-fold (0.13 log units) above it; the range from low to high includes it.
By their numbers in this assay, from the lowest: compound 3; then compounds 4 and 2 (each within the scatter of the next). At a limit, above all of these: compound 1.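

With fluoro in place of methyl on this aromatic carbon, this assay gives a measured number for the 3-fluorophenyl compound 4 where the 3-methylphenyl compound 1 gave none. The change reads as an at least 1.3-fold lower number from compound 1 to compound 4 (0.12 log units; that floor lies within the scatter) and so does not establish a real shift at this position. Its true size cannot be fixed because compound 1 rests at a limit: the limit of > 100000 nM in this assay, at which 1 of the 4 values shown sits.

From the compounds shown here alone, how an amine or a methoxy group at this position would read stays open. So does whether this swap behaves the same way on any other core.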